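The compounds below may be only part of what the source reports. "The series", "measured", "known", "first", "only" and "open" are said of these compounds alone.

Measured so far in a functional assay on the whole organism (strain Wistar Albino) for inhibition, with Rattus norvegicus as the target, read by paw edema, with a stated time of 2 h, at a dose of 20 mg/kg; on this read-out lower numbers stand for less inhibition and higher numbers for more inhibition at the one dose given (going by the name of the read-out):
- compound 1, `COc1ccc(Cl)c(-c2nnc3n2NC(c2ccc([N+](=O)[O-])o2)S3)c1`, gives 18.5%
- compound 2, `COc1ccc(Cc2nnc3n2NC(c2ccc([N+](=O)[O-])o2)S3)cc1OC`, gives 17.6%
- compound 3, `COc1ccc(Cl)c(-c2nnc3n2NC(c2ccc[nH]2)S3)c1`, gives 15.2%

Among the measured compounds shown here, all three numbers sit close together, and no pair of them is separated by more than the usual scatter of this kind of measurement, so none of the three can be called stronger or weaker than another on this evidence.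

Compound 1 and compound 3 differ in one place: 1H-pyrrol-2-yl in place of 5-nitrofuran-2-yl on a saturated ring carbon. The step that this change made is a number 3.3 percentage points lower from compound 1 to compound 3 (within the scatter). Compound 2 and compound 1 share the same kind of fused core, but how the two cores differ is not broken down here.

Compound 4, `COc1ccc(Cc2nnc3n2NC(c2ccc[nH]2)S3)cc1OC`, has not yet been tested. It stands to compound 2 exactly as compound 3 stands to compound 1: 1H-pyrrol-2-yl in place of 5-nitrofuran-2-yl on a saturated ring carbon. The surroundings of the exchanged group are the same word for word in both pairs, so this is the same change made a second time, on the core of compound 2 instead of the core of compound 1.

For the measured compounds named here, the only guide to its effect is the one earlier step. Because that step was a number 3.3 percentage points lower from compound 1 to compound 3 (within the scatter), the step from compound 2 to compound 4 is expected to be of similar size, a number 3.1 percentage points lower from compound 2 to compound 4 (within the scatter), with the understanding that a single within-scatter step is a weak guide and the true step could fall on either side of zero. Compound 4 is therefore estimated to give 14.5% in this assay, most likely between 6% and 23%.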

Compound 4, a percentage reported as inhibition, in the whole organism at one dose (the size of the read-out at that dose, not a potency): 15.9%
The estimate for compound 4 lay 1.4 percentage points below the measured number, within the range that was stated.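

Made a second time, on a different core, the exchange of 5-nitrofuran-2-yl for 1H-pyrrol-2-yl gives a number 1.7 percentage points lower from compound 2 to compound 4 (within the scatter) in this assay. Set beside the first case, the exchange looks much the same on both cores: the same change on two cores in this assay, a number 3.3 percentage points lower (within the scatter) from compound 1 to compound 3 and a number 1.7 percentage points lower (within the scatter) from compound 2 to compound 4, 1.6 percentage points apart, within the scatter of two such steps This shows that nothing in these two pairs separates the effect of the exchange on one core from its effect on the other, but it does not show that the exchange truly lowers the inhibition, since each step on its own could be scatter, and it does not show that a step of this size would hold on any core beyond these two.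

The compounds shown leave open whether a different group on the saturated ring carbon, such as a plain phenyl ring or a carboxylic acid, would give a number clearly apart from those seen here. They also leave open whether an amine or a longer chain in place of the methoxy-bearing aromatic group on the core would move the read-out beyond the scatter, and whether the exchange would then still behave in the same way.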